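The source may report more compounds than this note shows. Statements on the series, on what has been measured and on what is new or still open speak of the compounds shown alone.

In a functional assay on WHCO1 cells (Homo sapiens) for antiproliferative activity, read by MTT assay, with a stated time of 48 h (on this read-out lower numbers stand for stronger inhibition and higher numbers for weaker inhibition), compound 1 `C=CCSS/C=C/C[S+]([O-])CCC` gives 37000 nM. Compound 2 `CCC[S+]([O-])C/C=C/SSC` gives 28000 nM. Among the compounds with values here, the step between these two is a 1.3-fold lower number from compound 1 to compound 2 (0.12 log units; within the scatter), so compound 1 stands level with its only numerical neighbour. Compound 3 `COc1ccc(CS/C=C\C[S+]([O-])Cc2ccc(OC)cc2)cc1` is recorded at > 200000 nM, which is a limit of the assay and not a number.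

Compound 4 `C=CCSS/C=C/C[S+]([O-])CCCO` has not yet been measured. It departs from compound 1 in one place: hydroxy in place of hydrogen on a saturated chain carbon, three bonds along the chain from a sulfur. Put another way, propyl becomes 3-hydroxypropyl, with hydroxy in place of hydrogen on a saturated chain carbon, three bonds along the chain from a sulfur. Within the data shown here, no measured compound carries a hydroxy group, and no measured step changes this exact place. Among the measured compounds shown here, the closest guide is the one measured step from compound 1, a 1.3-fold lower number from compound 1 to compound 2 (0.12 log units; within the scatter), which alters a different group and stays within the scatter. On that slim basis, no change beyond the scatter is expected in this assay, and no direction is firmly favoured. The expected step is a 1.1-fold higher number from compound 1 to compound 4 (0.03 log units; within the scatter). Compound 4 is estimated at 40000 nM, with an expected range from 18000 nM to 90000 nM.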

Compound 4, half-maximal inhibitory concentration: 27000 nM
Estimate against measurement, compound 4: 1.5-fold (0.17 log units) above, within the range that was stated.
By their numbers in this assay, from the lowest: compounds 4, 2 and 1 (each within the scatter of the next). At a limit, above all of these: compound 3.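

In this assay the change from propyl to 3-hydroxypropyl gives a 1.4-fold lower number from compound 1 to compound 4 (0.14 log units; within the scatter). Within the data shown here, this is the first measured step at this place and the first measured compound to carry a hydroxy group, and it shows that hydroxy in place of hydrogen on a saturated chain carbon, three bonds along the chain from a sulfur, leaves the value of compound 1 within the scatter in this test. Nothing shown here gives a reason for this outcome.

Going by these compounds, whether an amine or a carboxylic acid in the same place, or a longer chain carrying the hydroxy group, would also stay within the scatter remains open. Also open, on these data alone, is whether the same change from propyl to 3-hydroxypropyl would read the same on compound 2, whose disulfide side differs from that of compound 1 by the step of a 1.3-fold lower number from compound 1 to compound 2 (0.12 log units; within the scatter).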